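Trimming the amine side chain: compound 3 to compound 4

The source may hold more compounds than are shown below. What is called first, only, known or untested is meant among the compounds shown, and "the series" means these compounds.

In a functional assay on ECa-109 cells (Homo sapiens) for antiproliferative activity, with a stated time of 72 h (a higher number here means a weaker inhibitor, a lower number a stronger inhibitor), compound 3 `COc1cc(OC)c(C(=O)/C=C/c2ccccc2Cl)c(O)c1CN(C)CCCN(C)C` gives 3800 nM, within the scatter of compound 1 `COc1cc(OC)c(C(=O)/C=C/c2ccccc2Cl)c(O)c1CN1CCCC1` at 6900 nM, while compound 2 `COc1cc(OC)c(C(=O)/C=C/c2ccccc2Cl)c(O)c1CN(C)CC(=O)O` gives 44400 nM. Compound 4 `COc1cc(OC)c(C(=O)/C=C/c2ccccc2Cl)c(O)c1CN(C)C` carries hydrogen in place of 2-(dimethylamino)ethyl on a saturated chain carbon bound to an amine nitrogen. Within the data shown here, the closest precedent is a 1.8-fold lower number from compound 1 to compound 3 (0.26 log units; within the scatter), an exchange of amine substituents that stays within the scatter. The larger moves, a 6.4-fold higher number from compound 1 to compound 2 (0.81 log units; beyond the scatter) and a 12-fold lower number from compound 2 to compound 3 (1.07 log units; beyond the scatter), both involve the carboxy group of compound 2, which compound 4 lacks. The expected change in this assay is a 1.4-fold higher number from compound 3 to compound 4 (0.16 log units; within the scatter), no step beyond the scatter. Compound 4 is estimated at 5500 nM, with an expected range of 2400 nM to 12500 nM.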

Compound 4, half-maximal inhibitory concentration: 2600 nM
Compound 4: middle estimate off by 2.1-fold (0.33 log units), on the high side; the measured number falls inside the stated range.
By their numbers in this assay, from the lowest: compounds 4, 3 and 1 (each within the scatter of the next, the first and the last beyond it); then compound 2.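

In this assay, cutting the side chain back to dimethylamino costs nothing measurable (a 1.5-fold lower number from compound 3 to compound 4 (0.16 log units; within the scatter)), so the 3-(dimethylamino)propyl chain is not required at this place. Hydrogen in place of carboxy on the saturated chain carbon gives a large gain (a 17-fold lower number from compound 2 to compound 4 (1.23 log units; beyond the scatter)), which leaves compound 2 as the only outlier among the four. Dimethylamino in place of pyrrolidin-1-yl gives a modest gain (a 2.7-fold lower number from compound 1 to compound 4 (0.42 log units; beyond the scatter)), the first step beyond the scatter between amines without carboxy. On these data alone, whether a morpholine or a primary amine on this carbon would hold the number remains open. No evidence here accounts for these steps.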